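Compound 3 to compound 4: a ring replaces a chain

The source may report more compounds than this note shows. Statements on the series, on what has been measured and on what is new or still open speak of the compounds shown alone.

Values in an ADME assay on microsomes from liver (Rattus norvegicus) for metabolic stability; on this read-out higher numbers stand for a longer-lived compound and lower numbers for a shorter-lived compound:
- Compound 1 `CC(C)C(c1ccc(-c2ccc3cccc(F)c3c2)[nH]c1=O)N1CCN/C1=N\C#N`: 0.327 h
- Compound 2 `CC(C)C(Cc1noc(=O)[nH]1)c1ccc(-c2ccc3cccc(F)c3c2)[nH]c1=O`: > 3 h
- Compound 3 `CC(C)NC(=O)CC(c1ccc(-c2ccc3cccc(F)c3c2)[nH]c1=O)C(C)C`: < 0.0667 h

In this assay compound 3 gives < 0.0667 h, which is a limit of the assay and not a number. Its steps from both other compounds put it at the short-lived end of the three. Compound 2 gives > 3 h, which is also a limit. Compound 1 gives a measured number, 0.327 h.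

Compound 4 `Cc1c[nH]c(C(c2ccc(-c3ccc4cccc(F)c4c3)[nH]c2=O)C(C)C)n1` differs from compound 3 in one place: 4-methyl-1H-imidazol-2-yl in place of (isopropylcarbamoyl)methyl on a saturated chain carbon bound to an aromatic carbon and a saturated chain carbon. The 4-methyl-1H-imidazol-2-yl group replaces (isopropylcarbamoyl)methyl on a saturated chain carbon bound to an aromatic carbon and a saturated chain carbon.

The closest measured step is an at least 4.9-fold lower number from compound 1 to compound 3 (0.69 log units; beyond the scatter), which exchanges a five-membered ring for the same chain at the same carbon. The step of an at least 44-fold lower number from compound 2 to compound 3 (1.65 log units; beyond the scatter) points the same way and is large. However, an at least 9.1-fold higher number from compound 1 to compound 2 (0.96 log units; beyond the scatter) shows that the two ring-bearing compounds differ widely, so the identity of the ring matters.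

A modest rise beyond the scatter is therefore expected, with compound 4 landing nearer compound 1 than compound 2. The expected change is an at least 3.7-fold higher number from compound 3 to compound 4 (0.57 log units; beyond the scatter). The estimate for compound 4 is 0.25 h, with an expected range from 0.07 h to 0.9 h.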

Compound 4, half-life: < 0.0667 h
Compound 4 ended at the assay's limit (the forecaster's own chance of this, stated with the estimate: 15%); middle value at least 3.7-fold (0.57 log units) away from the limit.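

Placing 4-methyl-1H-imidazol-2-yl on this saturated chain carbon gives an at least 44-fold lower number from compound 2 to compound 4 (1.65 log units; beyond the scatter), so a five-membered aromatic ring at this position does not by itself bring a long half-life in this assay. Set against the five-membered non-aromatic ring, the same group gives an at least 4.9-fold lower number from compound 1 to compound 4 (0.69 log units; beyond the scatter), and with this result, compounds carrying a ring at this carbon reach the short-lived end of the read-out, which among the earlier compounds only the open-chain compound 3 had occupied. The step between compound 3 and compound 4 cannot be read, because both compounds sit at the same assay limit: the limit of < 0.0667 h in this assay, at which 2 of the 4 values shown sit.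

On these data alone, how far compound 3 and compound 4 actually lie beyond that limit stays open, so the chain and the methylimidazole ring cannot be ranked against each other. Also open, as far as these compounds go, is whether a carboxylic acid or an imidazol-2-yl group without the methyl, placed on the same carbon, would fall nearer compound 2 or compound 4, and so which features of the ring in compound 2 go with its long half-life.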